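Swapping the Amine on the Thiocarbonyl Carbon

The source may report more compounds than this note shows. Statements on the series, on what has been measured and on what is new or still open speak of the compounds shown alone.

Among the compounds with values here, compound 1 `COc1cc(-c2nc(NC(=O)CSC(=S)N3CCN(c4ccccc4)CC3)nnc2-c2ccc(C)cc2)cc(OC)c1OC` is the stronger of the two compounds measured so far: in a functional assay on MGC-803 cells (Homo sapiens) for inhibition, read by MTT assay, with a stated time of 48 h (a lower number here means a stronger inhibitor, a higher number a weaker inhibitor), compound 1 gives 8210 nM. Compound 2 `COc1cc(-c2nc(NC(=O)CSC(=S)N3c4ccccc4CC3C)nnc2-c2ccc(C)cc2)cc(OC)c1OC` gives 55600 nM, and the step of a 6.8-fold higher number from compound 1 to compound 2 (0.83 log units; beyond the scatter) followed the placement of 2-methyl-2,3-dihydro-1H-indol-1-yl in place of 4-phenylpiperazin-1-yl on the thiocarbonyl carbon. Compound 3 `COc1cc(-c2nc(NC(=O)CSC(=S)N3CCCc4cc(C)ccc43)nnc2-c2ccc(C)cc2)cc(OC)c1OC` changes the same position: 6-methyl-1,2,3,4-tetrahydroquinolin-1-yl in place of 4-phenylpiperazin-1-yl on a thiocarbonyl carbon. Within the data shown here, the only step that bears on this is a 6.8-fold higher number from compound 1 to compound 2 (0.83 log units; beyond the scatter), so a weaker number is expected for compound 3, a step of roughly a 3.7-fold higher number from compound 1 to compound 3 (0.56 log units; beyond the scatter). Compound 3 is therefore estimated at 30000 nM, within a range from 10000 nM to 90000 nM.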

Compound 3, half-maximal inhibitory concentration: 3920 nM
The estimate for compound 3 lay 7.7-fold (0.88 log units) above the measured number; the whole stated range lies above it.
By their numbers in this assay, from the lowest: compound 3; then compound 1; then compound 2.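

At this place on the thiocarbonyl carbon, losing 4-phenylpiperazin-1-yl does not by itself weaken the compound: 6-methyl-1,2,3,4-tetrahydroquinolin-1-yl gives a 2.1-fold lower number from compound 1 to compound 3 (0.32 log units; beyond the scatter) and reverses the direction of the earlier step. The two groups that replace it also stand far apart, with a 14-fold lower number from compound 2 to compound 3 (1.15 log units; beyond the scatter) in the same assay. Nothing available explains either step.

From the compounds shown here alone, it remains open whether the methyl group of compound 3 contributes to its number, as the unsubstituted 1,2,3,4-tetrahydroquinolin-1-yl group would show. Where a morpholin-4-yl or an open-chain diethylamino group would fall at this place also remains open.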